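A few compounds are considered here, and "the series" means these few. Any claim that something is new, unique, unknown or untested is made for them only; others in the source may bear on it.

Going by the values given here, in a functional assay on CCRF-CEM cells (Homo sapiens) for inhibition (a higher number here means a weaker inhibitor, a lower number a stronger inhibitor), compound 1 `OC[C@H]1OC(n2cnc3c(-c4ccc(F)c(F)c4)ncnc32)[C@H](O)[C@@H]1O` gives 1400 nM, the lower of the two numbers so far, which makes it the stronger inhibitor of the pair. Compound 2 `CC(=O)OC[C@H]1O[C@@H](n2cnc3c(-c4ccc(F)c(F)c4)ncnc32)[C@H](OC(C)=O)[C@@H]1OC(C)=O` gives 8300 nM. Compound 3 `CCOc1ccc(-c2ncnc3c2ncn3C2O[C@H](CO)[C@@H](O)[C@H]2O)cc1` has not been measured. It keeps the core of compound 1 but carries 4-ethoxyphenyl in place of 3,4-difluorophenyl on an aromatic carbon. Among the compounds with values here, no measured pair shows a change of this kind, so the forecast is loose. A moderate step in this assay towards a higher number, meaning a weaker inhibitor, is expected. The estimated change is a 2.1-fold higher number from compound 1 to compound 3 (0.33 log units; beyond the scatter). For compound 3 the expected value is 3000 nM, within an estimated range from 700 nM to 13000 nM.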

Compound 3, half-maximal inhibitory concentration: 600 nM
For compound 3 the middle estimate is 5.0-fold (0.70 log units) above the measured one; measured number below the stated range.
By their numbers in this assay, from the lowest: compound 3; then compound 1; then compound 2.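

Changing the aromatic group on the shared core moves the result in this assay: 4-ethoxyphenyl in place of 3,4-difluorophenyl gives a 2.3-fold lower number from compound 1 to compound 3 (0.37 log units; beyond the scatter). This position therefore accepts a ring without fluorine that carries an ethoxy chain, and inhibition improves modestly. Nothing available explains why the step runs this way.

As far as these compounds go, whether the gain comes from adding the ethoxy group or from losing the two fluorines remains open. An unsubstituted phenyl, a shorter methoxy group, a longer butoxy chain or an amine on the ring could begin to separate these possibilities.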